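This account rests on a few compounds, and the source may have more. Where it says the series, first, only, none or still open, it means among the compounds named here.

Among the compounds with values here, in a functional assay on Jurkat cells (Homo sapiens) (a lower number here means a stronger inhibitor, a higher number a weaker inhibitor), three compounds built on the same core have numbers so far: compound 1 `C[C@H](NC(=O)C(=O)NCC1CCCCC1)C(=O)N[C@@H](CC(=O)O)C(=O)COc1c(F)c(F)cc(F)c1F` gives 19 nM, compound 2 `C[C@H](NC(=O)C(=O)Nc1cccnc1N(C)C)C(=O)N[C@@H](CC(=O)O)C(=O)COc1c(F)c(F)cc(F)c1F` gives 27 nM, and compound 3 `Cc1cccc(CNC(=O)C(=O)N[C@@H](C)C(=O)N[C@@H](CC(=O)O)C(=O)COc2c(F)c(F)cc(F)c2F)c1` gives 127 nM, the highest of the three. Compound 4 `Cc1ccc(CNC(=O)C(=O)N[C@@H](C)C(=O)N[C@@H](CC(=O)O)C(=O)COc2c(F)c(F)cc(F)c2F)c(C)c1` differs from compound 3 in one group, with 2,4-dimethylphenyl in place of 3-methylphenyl on a saturated chain carbon bound to an amide-type nitrogen. The nearest evidence comes from a 6.7-fold higher number from compound 1 to compound 3 (0.83 log units; beyond the scatter) and a 4.7-fold higher number from compound 2 to compound 3 (0.67 log units; beyond the scatter). Both steps are modest, but each swaps a quite different group, and neither compares two substituted phenyl groups. The expected result in this assay is therefore no change beyond the scatter, an estimated 1.3-fold lower number from compound 3 to compound 4 (0.10 log units; within the scatter). For compound 4 the estimated value is 100 nM, with a range of 35 nM to 280 nM.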

Compound 4, half-maximal inhibitory concentration: > 10000 nM
Compound 4: a limit, no number (the forecaster's own chance of this, stated with the estimate: 2%); at least 100-fold (2.00 log units) between middle value and limit.
By their numbers in this assay, from the lowest: compounds 1 and 2 (each within the scatter of the next); then compound 3. At a limit, above all of these: compound 4.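

In this assay compound 4 gives a limit of the assay, not a number: the limit of > 10000 nM in this assay, at which 1 of the 4 values shown sits. Going from 3-methylbenzyl to 2,4-dimethylbenzyl adds only one carbon, yet it gives an at least 78-fold higher number from compound 3 to compound 4 (1.89 log units; beyond the scatter), so small changes to the benzyl group on this amide-type nitrogen can matter greatly. The gaps to the other groups are an at least 370-fold higher number from compound 2 to compound 4 (2.56 log units; beyond the scatter) and an at least 520-fold higher number from compound 1 to compound 4 (2.72 log units; beyond the scatter).

The compounds shown leave open which of the two methyl groups in 2,4-dimethylbenzyl matters. From the compounds shown here alone, how an unsubstituted benzyl or a methoxy-bearing benzyl would behave also remains open.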